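Swapping trifluoromethoxy for methoxy on a weak growth inhibitor

This account rests on a few compounds, and the source may have more. Where it says the series, first, only, none or still open, it means among the compounds named here.

Measured in a functional assay on Bel-7402 cells (Homo sapiens) for inhibition, read by MTT assay, with a stated time of 24 h, tested at 1 ug/mL; on this read-out lower numbers stand for less inhibition of growth and higher numbers for more inhibition of growth at the one concentration tested:
compound 1 `O=C(CCCCC(S)CCS)Nc1ccccc1`: 1.32%
compound 2 `O=C(CCCCC(S)CCS)Nc1ccc(OC(F)(F)F)cc1`: 7.32%

These two values lie within the usual scatter of each other, so compound 2 cannot be separated from compound 1. Compound 3 `COc1ccc(NC(=O)CCCCC(S)CCS)cc1` is made from compound 2 by one change, methyl in place of trifluoromethyl on an oxygen on an aromatic ring. Among the compounds with values here, the only measured step that bears on this is a number 6 percentage points higher from compound 1 to compound 2 (within the scatter), which introduced the trifluoromethoxy group. Within the data shown here, with only that small step to go on, no change beyond the scatter is expected in this assay. The estimated change is a number 2.3 percentage points lower from compound 2 to compound 3 (within the scatter). For compound 3 the expected value is 5%, with an estimated range of 0% to 14%.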

Compound 3, percent growth inhibition at one concentration: 3.96%
Beside the measured number, compound 3's estimate is 1 percentage points above it; measured number inside the range.
By their numbers in this assay, from the lowest: compounds 1, 3 and 2 (each within the scatter of the next).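

Within this assay methyl in place of trifluoromethyl on the oxygen gives a number 3.4 percentage points lower from compound 2 to compound 3 (within the scatter) and methoxy in place of hydrogen on the aromatic carbon gives a number 2.6 percentage points higher from compound 1 to compound 3 (within the scatter). At this position, then, hydrogen, methoxy and trifluoromethoxy cannot be told apart at the one concentration tested. Nothing available here offers an explanation for these small differences. Still open, on these data alone, is whether an amine, a carboxylic acid or a longer chain at this position would move growth inhibition beyond the scatter. Also open, as far as these compounds go, is how these compounds behave at higher concentrations.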